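Same atoms, joined differently, on the shared core

The compounds below may be only part of what the source reports. "The series", "measured", "known", "first", "only" and "open" are said of these compounds alone.

Compound 1 `CN(C)S(=O)(=O)CCNc1nonc1/C(=N/O)Nc1ccc(F)c(Br)c1` gives 105 nM in an assay on isolated protein for inhibition of Indoleamine 2,3-dioxygenase 1 (Homo sapiens), read by fluorescence, with a stated time of 60 min; on this read-out lower numbers stand for stronger inhibition and higher numbers for weaker inhibition. Compound 2 `O=S(=O)(CCNc1nonc1/C(=N/O)Nc1ccc(F)c(Br)c1)NO` gives 126 nM in this assay, and the change from a 1.2-fold higher number from compound 1 to compound 2 (0.08 log units; within the scatter), so the two numbers sit within the usual scatter of each other and compound 2 cannot be set apart from compound 1. Compound 3 `NS(=O)(=O)CCONc1nonc1/C(=N/O)Nc1ccc(F)c(Br)c1` carries the same atoms as compound 2 arranged otherwise: 2-sulfamoylethoxy in place of 2-(hydroxysulfamoyl)ethyl on a nitrogen on an aromatic ring. For the measured compounds named here, the only measured step, from compound 1 to compound 2, touched solely the substituent on the sulfonyl sulfur and stayed within the scatter; no measured pair tests the rearranged linker itself, so the evidence is thin. The expected step for compound 3 is therefore a 1.3-fold higher number from compound 2 to compound 3 (0.10 log units; within the scatter), small and of uncertain direction. Compound 3 is estimated at 160 nM in this assay, with a range from 50 nM to 600 nM.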

Compound 3, half-maximal inhibitory concentration: 87 nM
Compound 3: middle estimate off by 1.8-fold (0.26 log units), on the high side, within the range that was stated.
By their numbers in this assay, from the lowest: compounds 3, 1 and 2 (each within the scatter of the next).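

In this assay, the exchange of 2-(hydroxysulfamoyl)ethyl for 2-sulfamoylethoxy on the nitrogen gives a 1.4-fold lower number from compound 2 to compound 3 (0.16 log units; within the scatter), and the exchange of 2-(dimethylsulfamoyl)ethyl for the same group gives a 1.2-fold lower number from compound 1 to compound 3 (0.08 log units; within the scatter). The earlier step had changed only the substituent on the sulfonyl sulfur, whereas these steps also change the chain attached to the nitrogen, and the numbers still cannot be set apart, even with one hydrogen-bond donor in the entering group against two in 2-(hydroxysulfamoyl)ethyl. No measurement is available that could explain why these numbers stay together.

Going by these compounds, with all three compounds within the scatter of one another, the change that would move the number at this place remains open. A longer chain, or an amine or a carboxylic acid at the chain end, could test this.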